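A few compounds are considered here, and "the series" means these few. Any claim that something is new, unique, unknown or untested is made for them only; others in the source may bear on it.

Compound 1 `CCN(CC)S(=O)(=O)c1ccc(S(=O)(=O)N2CCC[C@@H](C(=O)N3CCC(O)CC3)C2)cc1`: 4710 nM
Compound 2 `CCN(CC)S(=O)(=O)c1ccc(S(=O)(=O)N2CCC[C@@H](C(=O)N3CCOCC3)C2)cc1`: 790 nM
Compound 3 `CCN(CC)S(=O)(=O)c1ccc(S(=O)(=O)N2CCC[C@@H](C(=O)N3CC[C@@H](OC)C3)C2)cc1`: 11500 nM

These three compounds share one core and differ only in the ring that sits on the carbonyl carbon. In a functional assay on BXPC-3 cells (Homo sapiens) for inhibition, read by MTT assay, with a stated time of 7 days (a lower number here means a stronger inhibitor, a higher number a weaker inhibitor), compound 1 gives 4710 nM, which places it second highest of the three numbers: compound 2 lies lower, a 6.0-fold lower number from compound 1 to compound 2 (0.78 log units; beyond the scatter), while compound 3 lies higher, a 2.4-fold higher number from compound 1 to compound 3 (0.39 log units; beyond the scatter). Between the two outer compounds the gap is large, a 15-fold higher number from compound 2 to compound 3 (1.16 log units; beyond the scatter).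

Compound 4 `CCN(CC)S(=O)(=O)c1ccc(S(=O)(=O)N2CCC[C@@H](C(=O)N3CCC(C(F)F)CC3)C2)cc1` keeps the ring of compound 1 on the carbonyl carbon but changes the group on that ring: difluoromethyl in place of hydroxy on a saturated ring carbon. The hydroxy leaves and a difluoromethyl enters on a saturated ring carbon, three ring bonds from the ring nitrogen.

Among the measured compounds shown here, no measured step swaps a group on the ring while keeping the ring itself. The steps from compound 1 to compound 2 and from compound 1 to compound 3 each exchange the whole ring; they show only that this part of the molecule can shift the result in this assay by modest to large amounts in either direction. For compound 4 they give no direction, so the expected step is small, a 1.1-fold higher number from compound 1 to compound 4 (0.03 log units; within the scatter), with a wide range around it. Compound 4 is estimated at 5000 nM, expected to fall between 1200 nM and 20000 nM.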

Compound 4, half-maximal inhibitory concentration: 450 nM
The estimate for compound 4 lay 11-fold (1.05 log units) above the measured number; measured number outside the range, below it.
By their numbers in this assay, from the lowest: compounds 4 and 2 (each within the scatter of the next); then compound 1; then compound 3.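

The change from hydroxy to difluoromethyl shows that the group on this saturated ring carbon matters on its own, without any exchange of the ring: in this assay the swap gives a 10-fold lower number from compound 1 to compound 4 (1.02 log units; beyond the scatter), a step of the large size earlier seen only when a whole ring was exchanged. The new ring also stands level with the morpholine-bearing compound, as a 1.8-fold lower number from compound 2 to compound 4 (0.24 log units; within the scatter) shows, so two different groups on the carbonyl carbon now give results within the scatter of each other, while a 26-fold lower number from compound 3 to compound 4 (1.41 log units; beyond the scatter) is the widest gap among these compounds. Nothing available here gives a measured reason for the size of this step.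

With a single swap at this ring carbon, the loss of hydroxy and the arrival of difluoromethyl cannot be told apart, and a plain methyl, a single fluorine, a trifluoromethyl or an amine in the same place would each help to separate them. On these data alone, it also remains open whether the same exchange would give a step of similar size on another ring, or with a longer chain in place of the diethyl groups on the sulfonamide of the shared core.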